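The source may report more compounds than this note shows. Statements on the series, on what has been measured and on what is new or still open speak of the compounds shown alone.

Measured so far:
- compound 1 `Oc1ccc(/C=N/NC(=S)Nc2ccccc2)cc1`: 242000 nM
- compound 2 `Oc1ccc(/C=N/NC(=S)Nc2ccccc2Cl)cc1`: 46800 nM

Compound 1 carries the bare phenyl ring of the shared core. In an assay for inhibition of ribonucleoside-diphosphate reductase RR1 (Homo sapiens), with a stated time of 30 min (on this read-out higher numbers stand for weaker inhibition and lower numbers for stronger inhibition), compound 1 gives 242000 nM, the highest of the two numbers seen, so it is the weaker inhibitor of the pair. Compound 2 differs by a single chloro on the aromatic carbon, and the step of a 5.2-fold lower number from compound 1 to compound 2 (0.71 log units; beyond the scatter) shows that this one exchange brought a clearly lower number.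

Compound 3 `Oc1ccc(/C=N/NC(=S)Nc2cccc(Cl)c2)cc1` has not yet been measured. Its difference from compound 1 is chloro in place of hydrogen on an aromatic carbon. This is the same kind of exchange as from compound 1 to compound 2, only at another place on the ring: meta to a large group. Among the measured compounds shown here, the one relevant step, a 5.2-fold lower number from compound 1 to compound 2 (0.71 log units; beyond the scatter), therefore suggests that a chloro entering here should again lower the number, though whether the place matters cannot be read from two compounds.

The expected change is a 4.0-fold lower number from compound 1 to compound 3 (0.61 log units; beyond the scatter). For compound 3 the estimate in this assay is 60000 nM, with a range from 20000 nM to 180000 nM.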

Compound 3, half-maximal inhibitory concentration: 29300 nM
Compound 3: middle estimate off by 2.0-fold (0.31 log units), on the high side; measured number inside the range.
By their numbers in this assay, from the lowest: compounds 3 and 2 (each within the scatter of the next); then compound 1.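

A chloro meta to a large group also lowers the number in this assay and the size of the change is an 8.3-fold lower number from compound 1 to compound 3 (0.92 log units; beyond the scatter). The lowering seen with compound 2 is therefore not confined to a single place on the ring, since the same exchange now works at two places. Compounds 2 and 3 lie within the scatter of each other, so these numbers do not separate the two places, and neither can be favoured over the other.

Nothing available here explains why a chloro lowers the number at either place. From the compounds shown here alone, it also remains open whether a different group at the place meta to a large group, such as a methyl group, a methoxy group or an amine, would lower the number as the chloro does.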